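Replacing the hydroxypropyl side chain with a cyclic carbamate

The source may report more compounds than this note shows. Statements on the series, on what has been measured and on what is new or still open speak of the compounds shown alone.

The three measured compounds share a core and differ only in the group on the chain carbon bound to sulfur. Compound 1 `CC(C)c1n[nH]c2c(NCc3ccc(-c4ccccn4)cc3)nc(SCC(O)C(F)(F)F)nc12` gives 690 nM in a functional assay on HT cells (Homo sapiens) for antiproliferative activity, read by fluorescence, with a stated time of 72 h (on this read-out lower numbers stand for stronger inhibition of growth and higher numbers for weaker inhibition of growth), compound 2 `CC(C)c1n[nH]c2c(NCc3ccc(-c4ccccn4)cc3)nc(SCCC(N)=O)nc12` gives 120 nM, and compound 3 `CCC(O)CSc1nc(NCc2ccc(-c3ccccn3)cc2)c2[nH]nc(C(C)C)c2n1` gives 273 nM. On these numbers compound 3 stands second highest of the three: its nearest neighbour is compound 2, with a 2.3-fold higher number from compound 2 to compound 3 (0.36 log units; beyond the scatter), and its furthest is compound 1, with a 2.5-fold lower number from compound 1 to compound 3 (0.40 log units; beyond the scatter).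

Compound 4 `CC(C)c1n[nH]c2c(NCc3ccc(-c4ccccn4)cc3)nc(SCC3CNC(=O)O3)nc12` is not yet measured. It differs from compound 3 in one place: 2-oxo-1,3-oxazolidin-5-yl in place of 1-hydroxypropyl on a saturated chain carbon bound to a sulfur. The entering group carries a carbonyl and a ring nitrogen donor in the position where compound 3 has a hydroxyl, which brings it closer to the carbamoylmethyl of compound 2 than to the hydroxypropyl of compound 3.

The step that bears most directly on this change is a 2.3-fold higher number from compound 2 to compound 3 (0.36 log units; beyond the scatter), which shows that the hydroxypropyl group is the weaker of the two measured side chains; a 5.8-fold lower number from compound 1 to compound 2 (0.76 log units; beyond the scatter) points the same way for the carbamoyl-bearing chain. The expectation for compound 4 is therefore a modest lowering of the number relative to compound 3, a 1.7-fold lower number from compound 3 to compound 4 (0.23 log units; within the scatter). The estimated value for compound 4 in this assay is 160 nM, with a range from 60 nM to 450 nM.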

Compound 4, concentration for 50% growth inhibition: 80 nM
The estimate for compound 4 lay 2.0-fold (0.30 log units) above the measured number, and the stated range covers the measured number.
By their numbers in this assay, from the lowest: compounds 4 and 2 (each within the scatter of the next); then compound 3; then compound 1.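

In this assay, among these compounds, a ring is tolerated on the saturated chain carbon bound to a sulfur, which the open-chain groups of the earlier compounds could not show: the 2-oxo-1,3-oxazolidin-5-yl group gives a 3.4-fold lower number from compound 3 to compound 4 (0.53 log units; beyond the scatter) and an 8.6-fold lower number from compound 1 to compound 4 (0.94 log units; beyond the scatter). Exchanging carbamoylmethyl for this ring gives a 1.5-fold lower number from compound 2 to compound 4 (0.18 log units; within the scatter), so these two carbonyl-bearing groups are not told apart here, and both stand lower than the two hydroxyl-bearing groups of compound 3 and compound 1, a pattern that none of the four compounds goes against. The data shown offer no measured explanation for these differences.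

The compounds leave open whether the result follows the carbonyl, the ring or the ring nitrogen, a question that an open-chain carbamate, a pyrrolidin-2-one or an oxazolidine without the carbonyl would address. They also leave open how this place responds to an amine, a carboxylic acid or a longer chain between the sulfur and the ring.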